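Pentyl in place of hydrogen on selenium, across two cores

This account rests on a few compounds, and the source may have more. Where it says the series, first, only, none or still open, it means among the compounds named here.

Compound 1 `CCCCC[Se]c1nc(NCc2ccc(SC)cc2)c2ccccc2n1`: in a functional assay on HT-29 cells (Homo sapiens) for cytotoxicity, read by MTT assay, with a stated time of 72 h (a lower number here means that less compound is tolerated, a higher number that more compound is tolerated), compound 1 gives > 100000 nM, a limit of the assay.
Compound 2 `CSc1ccc(CNc2nc([SeH])nc3ccccc23)cc1`: in this assay compound 2 gives > 100000 nM, also a limit.
Compound 3 `Nc1nc([SeH])nc2ncccc12`: in this assay compound 3 gives > 100000 nM, again a limit.

The change pentyl in place of hydrogen on a selenium gives a step that the two limits leave unreadable from compound 2 to compound 1. The same change, (pentyl in place of hydrogen on a selenium), leads to compound 4 `CCCCC[Se]c1nc(N)c2cccnc2n1`; the difference between the two cores is not broken down here. All three measured values sit at the limit of > 100000 nM in this assay, at which 3 of the 3 values shown sit, so the step itself stays unread. On that basis compound 4 is expected to show a step that the limit leaves unreadable from compound 3 to compound 4. The estimate for compound 4 in this assay is 120000 nM, most likely another limit rather than a number.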

Compound 4, concentration lethal to 50% of the cells: 62100 nM
Compound 4: middle estimate off by 1.9-fold (0.29 log units), on the high side, and the stated range covers the measured number.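

In this assay, pentyl in place of hydrogen on a selenium gives an at least 1.6-fold lower number from compound 3 to compound 4 (0.20 log units; that floor lies within the scatter), so this pair shows a lower number at most weakly and does not establish a real change. The same change on the core of compound 2 gives a step that cannot be read, so nothing shows whether the change carries from one core to the other. That comparison stays unresolved because compound 4 alone has a measured number: the limit of > 100000 nM in this assay, at which 3 of the 4 values shown sit.

Left open is how a longer chain or a benzyl group in place of pentyl on the selenium would read in this assay, on either core.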